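The compounds below may be only part of what the source reports. "The series", "measured", "known", "first", "only" and "open" are said of these compounds alone.

Series around the shared core of compound 1 `O=C(CO[N+](=O)[O-])NNC(=O)c1ccc(-n2[nH]c(=O)cc2-c2ccccc2)cc1`. In a functional assay on the whole organism (strain Wistar) for inhibition, with Rattus norvegicus as the target, read by paw edema, with a stated time of 1 h, at a dose of 6 mg/kg by the oral route (on this read-out lower numbers stand for less inhibition and higher numbers for more inhibition at the one dose given (going by the name of the read-out)), compound 1 gives 19.8%. Compound 2 `CCOC(=O)c1c(-c2ccc([N+](=O)[O-])cc2)n(-c2ccc(C(=O)NNC(=O)CO[N+](=O)[O-])cc2)[nH]c1=O` gives 27.8% in this assay, and compound 3 `CCOC(=O)c1c(-c2ccccc2O)n(-c2ccc(C(=O)NNC(=O)CO[N+](=O)[O-])cc2)[nH]c1=O` gives 27.8% there. Compound 3 stands level with compound 2 at the digits recorded, the two together the highest of the three numbers, while compound 1 sits lower by a gap that is still within the scatter, so no order can be read among the three. Within the data shown here, the one step of a single change, no change at the digits printed from compound 2 to compound 3 (within the scatter), puts 2-hydroxyphenyl in place of 4-nitrophenyl on an aromatic carbon.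

Compound 4 `CCOC(=O)c1c(-c2ccccc2)n(-c2ccc(C(=O)NNC(=O)CO[N+](=O)[O-])cc2)[nH]c1=O` is not yet measured in this assay. hydrogen in place of hydroxy on an aromatic carbon Cut one bond further out, this reads 2-hydroxyphenyl to phenyl. Among the measured compounds shown here, the only step that bears on it is the one from compound 2 to compound 3, where a different aryl group at the same place left the number unchanged; a further exchange there is therefore expected to give no step beyond the scatter, a number 1.8 percentage points lower from compound 3 to compound 4 (within the scatter). Compound 4 is expected at 26%, within 16% to 36%.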

Compound 4, a percentage reported as inhibition, in the whole organism at one dose (the size of the read-out at that dose, not a potency): 54%
Estimate against measurement, compound 4: 28 percentage points below; measured number outside the range, above it.
By their numbers in this assay, from the lowest: compounds 1, 2 and 3 (each within the scatter of the next); then compound 4.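

In this assay, hydrogen in place of hydroxy on an aromatic carbon gives a number 26.2 percentage points higher from compound 3 to compound 4 (beyond the scatter) and hydrogen in place of nitro gives a number 26.2 percentage points higher from compound 2 to compound 4 (beyond the scatter) so the position is not indifferent to exchange, as the flat step between the two substituted aryl groups had suggested, and the plain phenyl stands above both. Ethoxycarbonyl in place of hydrogen on an aromatic carbon gives a number 34.2 percentage points higher from compound 1 to compound 4 (beyond the scatter) which makes this the first single change on the core of compound 1 that reads beyond the scatter. Nothing available here bears on why these steps take this size.

Open, going by these compounds, is whether an amine or a methoxy group on the phenyl keeps the number of compound 4. Also open, on these data alone, is whether a carboxylic acid or a longer ester chain can stand in place of the ethoxycarbonyl with the same gain.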